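Swapping the amide side chain of compound 3 for a carboxymethyl group

The source may report more compounds than this note shows. Statements on the series, on what has been measured and on what is new or still open speak of the compounds shown alone.

Measured so far:
- compound 1, `CCN(CC)CCNC(=O)c1ccc(C(CC)(CC)c2ccc(OCC(=O)C(C)(C)C)c(C)c2)n1CC`: 620 nM
- compound 2, `CCn1c(C(=O)NCCCN(C)C)ccc1C(CC)(CC)c1ccc(OCC(=O)C(C)(C)C)c(C)c1`: 960 nM
- compound 3, `C#CCNC(=O)c1ccc(C(CC)(CC)c2ccc(OCC(O)C(C)(C)C)c(C)c2)n1CC`: > 50000 nM

In a functional assay on HepG2 cells (Homo sapiens), read by MTT assay, with a stated time of 48 h (on this read-out higher numbers stand for weaker inhibition and lower numbers for stronger inhibition), compound 1 gives 620 nM. Compound 2 gives 960 nM in this assay, and the step of a 1.5-fold higher number from compound 1 to compound 2 (0.19 log units; within the scatter) shows that exchanging one basic amine on the amide side chain for another leaves the read-out essentially unchanged. Compound 3 stands apart: in this assay compound 3 reaches only the limit > 50000 nM, which is a boundary of the assay and not a number, and the limit of > 50000 nM in this assay, at which 1 of the 3 values shown sits, records that one of the three values sits there.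

Compound 4, `CCn1c(C(=O)N(C)CC(=O)O)ccc1C(CC)(CC)c1ccc(OCC(O)C(C)(C)C)c(C)c1`, has not yet been measured. It differs from compound 3 by (carboxymethyl)(methyl)amino in place of propargylamino on a carbonyl carbon. Among the compounds with values here, no measured step covers this change; the only step available, a 1.5-fold higher number from compound 1 to compound 2 (0.19 log units; within the scatter), concerns two basic side chains on compounds that both read in the sub-micromolar range and says nothing about a carboxymethyl group. With compound 3 already at the limit, there is no measured pull toward stronger inhibition to lean on. Compound 4 is therefore expected to remain very weak, with a step of a number no higher from compound 3 to compound 4 (the limit leaves the size open) estimated, most likely again ending at the limit. The estimate for compound 4 in this assay is 50000 nM, within a range from 10000 nM to 200000 nM.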

Compound 4, half-maximal inhibitory concentration: 17100 nM
The estimate for compound 4 lay 2.9-fold (0.47 log units) above the measured number; the range from low to high includes it.
By their numbers in this assay, from the lowest: compounds 1 and 2 (each within the scatter of the next); then compound 4. At a limit, above all of these: compound 3.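

In this assay, within the data shown here, the step of an at least 2.9-fold lower number from compound 3 to compound 4 (0.46 log units; beyond the scatter) shows that the group on this carbonyl carbon can move the read-out beyond the scatter, whereas the only earlier step, a 1.5-fold higher number from compound 1 to compound 2 (0.19 log units; within the scatter), stayed within it. The change behind this new step is (carboxymethyl)(methyl)amino in place of propargylamino, which removes a triple bond and brings in oxygen atoms and a hydrogen-bond acceptor, and it gives compound 4 a real number rather than a limit. Compound 3 is recorded only as a limit and not a number, so the full size of the step stays unknown, because it starts from that boundary: the limit of > 50000 nM in this assay, at which 1 of the 4 values shown sits.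

This single step also changes several things at once, so it cannot say whether the propargyl group's departure, the carboxylic acid's arrival or the methyl on the amide nitrogen accounts for the shift. A methyl ester in place of the carboxylic acid, or a plain methylamino group on the same carbonyl carbon with the rest of compound 3 kept, would be needed to pull these parts apart.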